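A few compounds are considered here, and "the series" means these few. Any claim that something is new, unique, unknown or untested is made for them only; others in the source may bear on it.

Working notes on the series. Compound 1 `COc1cc(/C=N/Nc2nc3ccccc3s2)cc(OC)c1O` and compound 3 `COc1cc(/C=N/Nc2nc3ccccc3s2)ccc1O` share one core; compound 2 `COc1cc(/C=N/N2C(=O)CSC2=S)cc(OC)c1O` carries a second core, and the difference between the two cores is not broken down here. In a physicochemical assay on cells (Homo sapiens), with a stated time of 18 h, tested at 10 uM (on this read-out higher numbers stand for a weaker effect at the one concentration tested and lower numbers for a stronger effect), compound 1 gives 3%, compound 3 gives 7% and compound 2 gives 5%. All three numbers lie close together: the gap between compound 2 and compound 1 and the gap between compound 2 and compound 3 are both within the scatter.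

Within the data shown here, the one counted step so far is hydrogen in place of methoxy on an aromatic carbon, and it made a number 4 percentage points higher from compound 1 to compound 3 (within the scatter). Compound 4 `COc1cc(/C=N/N2C(=O)CSC2=S)ccc1O` is the unmeasured member; it differs from compound 2 by hydrogen in place of methoxy on an aromatic carbon. This is the same kind of change as that from compound 1 to compound 3: the surroundings agree in being ortho to a hydroxy group and meta to a methoxy group, and differ only in that the third neighbour is a group of 9 heavy atoms on compound 2 against a large group on compound 1.

Because a number 4 percentage points higher from compound 1 to compound 3 (within the scatter) stayed within the scatter, the expectation for compound 4 in this assay is a step of about the same size, a number 3 percentage points higher from compound 2 to compound 4 (within the scatter), likewise expected to stay within the scatter. For compound 4 the estimated value is 8%. The lower end estimated for compound 4 is 0%. The upper end estimated for compound 4 is 22%. The measurement will show whether the small step seen on the core of compound 1 recurs on the core of compound 2.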

Compound 4, a percentage reported as activity, at one concentration (the size of the read-out at that concentration, not a potency): 5%
Beside the measured number, compound 4's estimate is 3 percentage points above it; the range from low to high includes it.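

In this assay hydrogen in place of methoxy on the aromatic carbon ortho to a hydroxy group gives no change at the digits printed from compound 2 to compound 4 (within the scatter) and, on the other core, a number 4 percentage points higher from compound 1 to compound 3 (within the scatter), so on both cores shown this change stays inside the usual scatter of the read-out. Among these compounds, this shows only that the change carries from one core to the other as a step that cannot be told from repeat noise; with two pairs and one tested concentration, it does not show that the change has a shared real effect on both cores, nor that it would stay this small on a further core, and it gives no potency. Nothing at hand bears on why the step is so small on either core.

The compounds shown hold only methoxy or hydrogen at this place, so it remains open whether an amine, a carboxylic acid or a longer chain such as ethoxy on that aromatic carbon would move the number in this assay beyond the scatter. Also open, on these data alone, is whether such a group would behave alike on both cores, which is the question the two small steps cannot settle.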